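Swapping Fluoro for Bromo on an Aromatic Carbon

The source may report more compounds than this note shows. Statements on the series, on what has been measured and on what is new or still open speak of the compounds shown alone.

Values so far from a functional assay on MCF7 cells (Homo sapiens) for cytotoxicity, read by MTT assay, with a stated time of 48 h (on this read-out higher numbers stand for weaker inhibition and lower numbers for stronger inhibition), in two lines:
Compound 1 `Fc1ccc(NC(=S)N/N=C\c2ccnc3ccccc23)cc1` gives 1100 nM as its value
Compound 2 `S=C(N/N=C\c1ccnc2ccccc12)Nc1cccc2ccccc12` gives 880 nM as its value

For the measured compounds named here, with only two measurements, the picture is small. Compound 1 sits level with compound 2, since their two values lie within the usual scatter of repeated measurements. Neither can be ranked above the other in this assay on these numbers.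

The next compound to be tested is compound 3 (`S=C(N/N=C\c1ccnc2ccccc12)Nc1ccc(Br)cc1`), which has no measured value yet. It differs from compound 1 in one place, with bromo in place of fluoro on an aromatic carbon, para to a large group (bromo in place of fluoro on an aromatic carbon). The same difference can be read as 4-fluorophenyl to 4-bromophenyl.

Going by the values given here, no measured pair shows what this exchange does, so the expectation rests on the level of compound 1 (1100 nM) and compound 2 (880 nM) alone. The expected outcome is a 1.2-fold lower number from compound 1 to compound 3 (0.09 log units; within the scatter) in this assay and this estimated step stays within the scatter. For compound 3 the estimated value is 900 nM (expected range 350 nM to 2500 nM).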

Compound 3, half-maximal inhibitory concentration: 990 nM
Estimate against measurement, compound 3: 1.1-fold (0.04 log units) below; the range from low to high includes it.
By their numbers in this assay, from the lowest: compounds 2, 3 and 1 (each within the scatter of the next).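

In this assay, for the compounds shown here, the one exchange that separates these two compounds gives a 1.1-fold lower number from compound 1 to compound 3 (0.05 log units; within the scatter), so on this read-out the two groups cannot be told apart at this position. The earlier values gave only a general level for the series, whereas this pair isolates a single difference, with the rest of the structure held the same, and shows that this particular exchange leaves the result within the usual scatter of repeated measurements. Nothing measured here speaks to why the two compounds sit level.

Going by these compounds alone, this single pair covers only two groups at this position, so it remains open whether an amine, a carboxylic acid or a methoxy group on the same aromatic carbon would stay at this level or move clearly away from it. On these data alone, it also remains open whether bromo and fluoro would again be indistinguishable on a different core or in a different assay, since one pair cannot establish a general rule.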